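The compounds below may be only part of what the source reports. "The series", "measured", "known", "first", "only" and "open" are said of these compounds alone.

Measured compounds in a functional assay on SW-620 cells (Homo sapiens) for inhibition, read by MTT assay, with a stated time of 72 h; on this read-out lower numbers stand for stronger inhibition and higher numbers for weaker inhibition:
- compound 1 `COc1cc(NC(C)CCCNC(=O)Nc2ccc(O)cc2)c2ncccc2c1`: 30000 nM
- compound 2 `COc1cc(NC(C)CCCNC(=O)NNC(=O)Nc2ccc(O)cc2)c2ncccc2c1`: a limit only, > 100000 nM
- compound 3 `COc1cc(NC(C)CCCNC(=O)NNC(=O)Nc2ccc(F)cc2)c2ncccc2c1`: a limit only, > 100000 nM

Compound 3 sits at the limit of this assay (the limit of > 100000 nM in this assay, at which 2 of the 3 values shown sit), so for it no number is known, only that it lies beyond that limit. Compound 2 sits at the same limit, so the step between compound 2 and compound 3 cannot be read: a step that the two limits leave unreadable from compound 2 to compound 3.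

Compound 4 `COc1cc(NC(C)CCCNC(=O)Nc2cccc(F)c2)c2ncccc2c1` differs from compound 3 in one place: 3-fluorophenyl in place of ((4-fluorophenyl)carbamoyl)amino on an amide-type nitrogen.

Going by the values given here, the steps that bear on this change run the other way, from compound 1: an at least 3.3-fold higher number from compound 1 to compound 2 (0.52 log units; beyond the scatter) and an at least 3.3-fold higher number from compound 1 to compound 3 (0.52 log units; beyond the scatter). Both show that inserting the carbamoylamino spacer between the amide-type nitrogen and the aryl ring moves the number from the value of compound 1 to beyond the limit. Compound 4 undoes that insertion and returns to a direct aryl urea, like compound 1 but with 3-fluorophenyl instead of 4-hydroxyphenyl. It is therefore expected to come back near compound 1, with a step from the limit of at least an at least 3.3-fold lower number from compound 3 to compound 4 (0.52 log units; beyond the scatter) downward in this assay. Compound 4 is estimated at 30000 nM, with a range from 10000 nM to 100000 nM.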

Compound 4, half-maximal inhibitory concentration: 27000 nM
Compound 4: the middle estimate sits 1.1-fold (0.05 log units) above what was measured; the measured number falls inside the stated range.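

In this assay, 3-fluorophenyl in place of ((4-fluorophenyl)carbamoyl)amino on the amide-type nitrogen gives an at least 3.7-fold lower number from compound 3 to compound 4 (0.56 log units; beyond the scatter), and in place of ((4-hydroxyphenyl)carbamoyl)amino it gives an at least 3.7-fold lower number from compound 2 to compound 4 (0.56 log units; beyond the scatter). Both sizes are bounds only, as compound 2 and compound 3 rest on a limit: the limit of > 100000 nM in this assay, at which 2 of the 4 values shown sit. With a 1.1-fold lower number from compound 1 to compound 4 (0.05 log units; within the scatter), 3-fluorophenyl and 4-hydroxyphenyl cannot be told apart on this nitrogen, so a fluorinated ring also gives a measurable value when no carbamoylamino unit is present, and the two rings so far shown there give the same reading.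

As far as these compounds go, whether any group on this nitrogen moves the number beyond that shared level remains open, for instance a phenyl ring carrying an amine or a carboxylic acid, or a longer chain. From the compounds shown here alone, how 4-fluorophenyl itself reads on this nitrogen also remains open, so the fluorine placement is not separated from the loss of the carbamoylamino unit.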